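The compounds below may be only part of what the source reports. "The series", "measured", "known", "first", "only" and "open" are said of these compounds alone.

Measured compounds:
- compound 1 `CN1CCN(c2nc3ccccc3n2CCOc2ccccc2)CC1`: 6.9 nM
- compound 2 `CCCCCCCn1c(N2CCN(C)CC2)nc2ccccc21`: 150 nM
- compound 3 `CCCCCCCCCCn1c(N2CCN(C)CC2)nc2ccccc21`: 4200 nM

These three share one core and differ only in the chain attached to it. In a functional assay on ileum for inhibition of histamine H1 receptor (Cavia porcellus) (a higher number here means a weaker inhibitor, a lower number a stronger inhibitor), compound 3 gives the highest of the three numbers, meaning the weakest inhibition: a 28-fold higher number from compound 2 to compound 3 (1.45 log units; beyond the scatter) and a 610-fold higher number from compound 1 to compound 3 (2.78 log units; beyond the scatter) both place it well beyond the scatter from the others.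

Compound 4 `CCCCOCCn1c(N2CCN(C)CC2)nc2ccccc21` is not yet measured. Its change from compound 3 is butoxy in place of octyl on a saturated chain carbon, two bonds along the chain from an aromatic nitrogen. This shortens the chain and brings in an ether oxygen, which makes the change resemble, in part, the reverse of the steps already seen: the reverse of a 28-fold higher number from compound 2 to compound 3 (1.45 log units; beyond the scatter) (a shorter chain) and the reverse of a 610-fold higher number from compound 1 to compound 3 (2.78 log units; beyond the scatter) (an oxygen-linked chain). Both of those steps were large, so a large step downward in this assay is expected for the move from compound 3 to compound 4, roughly a 53-fold lower number from compound 3 to compound 4 (1.72 log units; beyond the scatter). Compound 4 is therefore estimated at about 80 nM, with a likely range from 15 nM to 400 nM.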

Compound 4, half-maximal inhibitory concentration: 38 nM
Estimate against measurement, compound 4: 2.1-fold (0.32 log units) above, and the stated range covers the measured number.
By their numbers in this assay, from the lowest: compound 1; then compound 4; then compound 2; then compound 3.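

In this assay butoxy in place of octyl gives a 110-fold lower number from compound 3 to compound 4 (2.04 log units; beyond the scatter) and butoxy in place of pentyl gives a 3.9-fold lower number from compound 2 to compound 4 (0.60 log units; beyond the scatter), so an oxygen-linked chain without a ring gives a lower number here than either all-carbon chain shown. The earlier comparisons shown here with compound 1 changed the oxygen and the phenyl ring together, whereas this result begins to separate them: butyl in place of phenyl on the same oxygen gives a 5.5-fold higher number from compound 1 to compound 4 (0.74 log units; beyond the scatter) and leaves compound 4 much closer to compound 1 than octyl left compound 3. At this position a phenyl ring is therefore not needed to reach a low number, although compound 1 with its phenoxy group still gives the lowest number of the four. Nothing measured here explains why these chains differ.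

The compounds shown leave open how the number would change with a shorter ether such as ethoxy or a longer one such as hexyloxy. They also leave open whether an amine in place of the ether oxygen would give a number closer to that of compound 4 or to those of the all-carbon chains.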